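Cytotoxicity notes on the step to compound 4

The source may hold more compounds than are shown below. What is called first, only, known or untested is meant among the compounds shown, and "the series" means these compounds.

Compound 1 (`CCCCCCC1C(=O)N(O)C(=O)c2ccccc21`) gives 4400 nM in an ADME assay on MT4 cells (Homo sapiens) for cytotoxicity, read by MTT assay (on this read-out higher numbers stand for lower toxicity in this test and lower numbers for higher toxicity in this test), and lies within the scatter of compound 3 (`O=C1c2ccccc2C(Cc2ccc(C(F)(F)F)cc2)C(=O)N1O`), which gives 6000 nM there. Compound 2 (`CC(C)C1C(=O)N(O)C(=O)c2ccccc21`) gives 123000 nM on the same read-out. Going by the values given here, the one measured single-place step is a 28-fold higher number from compound 1 to compound 2 (1.45 log units; beyond the scatter) with isopropyl in place of hexyl on a saturated ring carbon, a large step. Compound 4 (`O=C1c2ccccc2C(CCc2ccccc2)C(=O)N1O`) carries phenyl in place of butyl on a saturated chain carbon, two bonds along the chain from a saturated ring carbon as its difference: phenyl in place of butyl on a saturated chain carbon, two bonds along the chain from a saturated ring carbon. The isopropyl step bears only loosely on this change. Compound 3 at 6000 nM also has an aromatic ring on its side group and stays level with compound 1. A much smaller step towards a higher number is therefore expected in this assay. The estimated step is a 3.4-fold higher number from compound 1 to compound 4 (0.53 log units; beyond the scatter) in that direction. The expected value for compound 4 is 15000 nM (range 5000 nM to 45000 nM).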

Compound 4, half-maximal cytotoxic concentration: 30000 nM
For compound 4 the middle estimate is 2.0-fold (0.30 log units) below the measured one; measured number inside the range.
By their numbers in this assay, from the lowest: compounds 1 and 3 (each within the scatter of the next); then compound 4; then compound 2.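

Phenyl in place of butyl on a saturated chain carbon, two bonds along the chain from a saturated ring carbon, gives a 6.8-fold higher number from compound 1 to compound 4 (0.83 log units; beyond the scatter) in this assay. The number therefore moves beyond the scatter when only the far end of the hexyl group of compound 1 changes, though this modest step is not as large as the isopropyl step. Nothing measured here accounts for the step. Going by these compounds, whether a longer chain carrying the phenyl ring, or an amine or carboxylic acid in its place, would shift the number remains open.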